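This account rests on a few compounds, and the source may have more. Where it says the series, first, only, none or still open, it means among the compounds named here.

Among the measured compounds shown here, in a functional assay on A549 cells (Homo sapiens) for cytotoxicity, with a stated time of 48 h (a higher number here means a weaker inhibitor of growth, a lower number a stronger inhibitor of growth), compound 1 (`Nc1nc(-c2cc(N3C[C@H](O)[C@@H](O)C3)ccc2O)cc(C2CCCCCC2)n1`) gives 600 nM, the only number available, and compound 2 (`CN(C)c1cc(-c2cc(N3C[C@H](O)[C@@H](O)C3)ccc2O)nc(N)n1`) is given as "not determined" (no result reported). Compound 3 (`Nc1nc(-c2cc(N3C[C@H](O)[C@@H](O)C3)ccc2O)cc(C2CCCC2)n1`) carries cyclopentyl in place of cycloheptyl on an aromatic carbon. For the measured compounds named here, no measured step shows what such a change does. With compound 1 at 600 nM as the sole anchor, only a modest shift toward a higher number is expected in this assay, possibly none beyond the scatter. The estimated step is a 1.7-fold higher number from compound 1 to compound 3 (0.22 log units; within the scatter) and it stays small. Compound 3 is expected at 1000 nM with a range from 350 nM to 3000 nM in this assay.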

Compound 3, concentration for 50% growth inhibition: 2000 nM
Beside the measured number, compound 3's estimate is 2.0-fold (0.30 log units) below it; the measured number falls inside the stated range.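

In this assay, this position on the aromatic carbon next to the ring nitrogen proves sensitive to the size of its carbocycle: cyclopentyl in place of cycloheptyl gives a 3.3-fold higher number from compound 1 to compound 3 (0.52 log units; beyond the scatter), a modest loss of growth inhibition beyond the scatter. Among the compounds shown here, this is the first measured step at this position, and it favours the seven-membered ring over the five-membered one in this pair. Nothing available explains the step. With only two numbers, the compounds shown leave open whether cyclohexyl would fall between them and whether the trend extends to larger rings. As far as these compounds go, how an open chain such as n-hexyl or an amine such as piperidine would fare at this position also remains open.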